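Amide-to-sulfonamide change on the anilide side of the series

This account rests on a few compounds, and the source may have more. Where it says the series, first, only, none or still open, it means among the compounds named here.

Of the compounds shown here, three of the shared core have been measured in a functional assay on MCF7 cells (Homo sapiens) for antiproliferative activity, read by MTT assay, with a stated time of 48 h; a higher number here means a weaker inhibitor, a lower number a stronger inhibitor. Compound 1 `O=C(Nc1cccc(/C=C/C(=O)c2nc3ccccc3[nH]2)c1)c1cccc(Cl)c1` gives 7840 nM, compound 2 `O=C(Nc1cccc(/C=C/C(=O)c2nc3ccccc3[nH]2)c1)c1cccc(Br)c1` gives 5210 nM and compound 3 `Cc1cc(C)cc(C(=O)Nc2cccc(/C=C/C(=O)c3nc4ccccc4[nH]3)c2)c1` gives 24600 nM. Compound 2 has the lowest number of the three, but the step of a 1.5-fold lower number from compound 1 to compound 2 (0.18 log units; within the scatter) is within the scatter, so compound 1 and compound 2 cannot be ordered. Against compound 3 the steps of a 3.1-fold higher number from compound 1 to compound 3 (0.50 log units; beyond the scatter) and a 4.7-fold higher number from compound 2 to compound 3 (0.67 log units; beyond the scatter) are beyond the scatter and modest, showing that the aryl group on the carbonyl carbon shifts the number.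

Compound 4 `Cc1ccccc1S(=O)(=O)Nc1cccc(/C=C/C(=O)c2nc3ccccc3[nH]2)c1` differs from compound 2 as follows: (2-methylphenyl)sulfonyl in place of (3-bromophenyl)carbonyl on a nitrogen on an aromatic ring. Going by the values given here, no measured step tests a sulfonyl in place of a carbonyl on this nitrogen, so the measured steps give only a sense of scale: a change of the aryl group moved the number modestly, and the present change is larger. The expectation is therefore a step of a 1.5-fold higher number from compound 2 to compound 4 (0.19 log units; within the scatter), with wide uncertainty in this assay. For compound 4 the estimated value is 8000 nM, in the range 2500 nM to 25000 nM.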

Compound 4, half-maximal inhibitory concentration: 4130 nM
For compound 4 the middle estimate is 1.9-fold (0.29 log units) above the measured one; low and high end bracket the measured number.
By their numbers in this assay, from the lowest: compounds 4, 2 and 1 (each within the scatter of the next); then compound 3.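

In this assay the swap of a (3-bromophenyl)carbonyl for a (2-methylphenyl)sulfonyl on the nitrogen gives a 1.3-fold lower number from compound 2 to compound 4 (0.10 log units; within the scatter) and the matching swap from the chloro amide gives a 1.9-fold lower number from compound 1 to compound 4 (0.28 log units; within the scatter) so compound 4 cannot be ordered against either halogenated amide, and this nitrogen accepts a sulfonyl in place of a carbonyl without a readable change from those two. Going by these compounds alone, the one step beyond the scatter is a 6.0-fold lower number from compound 3 to compound 4 (0.77 log units; beyond the scatter) and it places compound 4 apart from the dimethylphenyl amide, with the same separation that compounds 1 and 2 already showed. No measurement at hand bears on what lies behind these steps.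

Within the data shown here, each step changes the linking group and the aryl substitution together, and no pair carries the same aryl group on both a carbonyl and a sulfonyl, so the two contributions remain unseparated. Open too, from the compounds shown here alone, is how a methylsulfonyl group, a urea linkage or an aryl ring bearing an amine or a carboxylic acid would behave on this nitrogen.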